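Removing a core chlorine from a dichloropurine benzyl chloride

This account rests on a few compounds, and the source may have more. Where it says the series, first, only, none or still open, it means among the compounds named here.

Three close analogues carry the same fused core and a benzyl group bearing a chloromethyl substituent. In a functional assay on MDA-MB-231 cells (Homo sapiens) for cytotoxicity, read by sulforhodamine B assay, with a stated time of 48 h (on this read-out lower numbers stand for stronger inhibition of growth and higher numbers for weaker inhibition of growth), compound 2 `ClCc1ccc(Cn2cnc3nc(Cl)nc(Cl)c32)cc1` gives 3090 nM, the highest of the three numbers. Compound 3 `ClCc1cccc(Cn2cnc3nc(Cl)nc(Cl)c32)c1` gives 1730 nM, which lies within the scatter of compound 2, whereas compound 1 `ClCc1ccccc1Cn1cnc2c(Cl)nc(Cl)nc21` gives 1380 nM, a number clearly lower than that of compound 2 and beyond the scatter.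

Compound 4 `ClCc1ccc(Cn2cnc3ncnc(Cl)c32)cc1` differs from compound 2 by hydrogen in place of chloro on an aromatic carbon. For the measured compounds named here, no measured pair shows the loss of this chlorine, so its effect is unknown; a modest step toward higher numbers, or none beyond the scatter, seems plausible. The step from compound 2 to compound 4 in this assay is estimated at a 1.5-fold higher number from compound 2 to compound 4 (0.16 log units; within the scatter). Compound 4 is therefore expected to give about 4500 nM, with a range of 1500 nM to 14000 nM.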

Compound 4, concentration for total growth inhibition: 3380 nM
The estimate for compound 4 lay 1.3-fold (0.12 log units) above the measured number; the measured number falls inside the stated range.
By their numbers in this assay, from the lowest: compounds 1, 3, 2 and 4 (each within the scatter of the next, the first and the last beyond it).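

In this assay, for the compounds shown here, hydrogen in place of chloro on the aromatic carbon between two ring nitrogen atoms gives a 1.1-fold higher number from compound 2 to compound 4 (0.04 log units; within the scatter) as the first measured step at this position. For this pair, the chlorine at this position can therefore be lost without a shift beyond the scatter. Nothing at hand explains this result.

From the compounds shown here alone, whether an amine, a methoxy group or a longer chain at this position would leave the number equally unmoved stays open. So does whether the same exchange would behave alike on compound 1 or compound 3.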